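This account rests on a few compounds, and the source may have more. Where it says the series, first, only, none or still open, it means among the compounds named here.

Measured compounds:
compound 1, `COc1nc(C)c(Nc2nc(Cl)cn([C@H](COC(=O)c3ccccn3)C3CC3)c2=O)cc1C`, 67 nM
compound 2, `COc1nc(C)c(Nc2nc(Cl)cn([C@H](COC(=O)c3cccnc3)C3CC3)c2=O)cc1C`, 5.2 nM
compound 3, `COc1nc(C)c(Nc2nc(Cl)cn([C@H](COC(=O)Nc3ccccc3)C3CC3)c2=O)cc1C`, 1.5 nM

In an assay on frontal cortex for displacement of a labelled ligand from corticotropin-releasing factor receptor 1 (Rattus norvegicus), with a stated time of 2 h (a higher number here means a weaker inhibitor, a lower number a stronger inhibitor), compound 1 gives 67 nM, the highest of the three numbers; the nearest to it is compound 2 with 5.2 nM, and the furthest is compound 3 with 1.5 nM. Compound 4, `COc1nc(C)c(Nc2nc(Cl)cn([C@H](COC(=O)Nc3ccc(Cl)cc3Cl)C3CC3)c2=O)cc1C`, has not yet been measured. Its change from compound 1 is (2,4-dichlorophenyl)amino in place of pyridin-2-yl on a carbonyl carbon. Among the measured compounds shown here, two measured steps bear on this. For the measured compounds named here, the step of a 45-fold lower number from compound 1 to compound 3 (1.65 log units; beyond the scatter) exchanges the same pyridin-2-yl for an anilino group on the same carbonyl carbon and is the closest precedent. The step of a 13-fold lower number from compound 1 to compound 2 (1.11 log units; beyond the scatter) shows that even a smaller exchange at this carbonyl carbon moves the number a long way, and a 3.5-fold lower number from compound 2 to compound 3 (0.54 log units; beyond the scatter) places the anilino compound lower still. Going by the values given here, compound 4 carries the anilino with two chlorines; no measured pair shows what the chlorines add, so the expectation rests on compound 3 at 1.5 nM alone. For compound 4 a large downward step is therefore expected, a 34-fold lower number from compound 1 to compound 4 (1.53 log units; beyond the scatter). Compound 4 is estimated at 2 nM, with a range from 0.5 nM to 8 nM.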

Compound 4, half-maximal inhibitory concentration: 1.7 nM
Beside the measured number, compound 4's estimate is 1.2-fold (0.07 log units) above it; measured number inside the range.
By their numbers in this assay, from the lowest: compounds 3 and 4 (each within the scatter of the next); then compound 2; then compound 1.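

In this assay, among the compounds shown here, the step of a 1.1-fold higher number from compound 3 to compound 4 (0.05 log units; within the scatter) is the first measured pair to isolate the chlorines, and it shows that 2,4-dichlorophenyl in place of phenyl on this amide-type nitrogen leaves the reading within the scatter. The group on the nitrogen can therefore carry this added bulk of two chlorines without losing what the anilino exchange gained, as the large step of a 39-fold lower number from compound 1 to compound 4 (1.60 log units; beyond the scatter) and the modest step of a 3.1-fold lower number from compound 2 to compound 4 (0.49 log units; beyond the scatter) both show. The material gives no measurement that explains why the two anilino-type compounds stand so close together.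

The compounds shown leave open whether a single chlorine, a methoxy group or a trifluoromethyl group on the phenyl ring would also sit within the scatter of these two, and whether a saturated ring such as cyclohexyl could take the place of the phenyl. They also leave open what happens when a methyl group replaces the amide hydrogen, which would show whether that hydrogen matters at this position.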